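The compounds below may be only part of what the source reports. "The series", "measured", "known", "first", "only" and "open" are said of these compounds alone.

The compounds here share one core and differ only in the group on an amide-type nitrogen in a ring, and they are tested in a functional assay on HeLa cells (Homo sapiens) for antiproliferative activity, read by MTT assay, with a stated time of 72 h; on this read-out higher numbers stand for weaker inhibition and lower numbers for stronger inhibition. With hydrogen at that place, compound 1 `O=C1COc2ccc(-c3cccc(NS(=O)(=O)c4ccc(F)cc4)c3)cc2N1` reads > 40000 nM, which is a limit of the assay and not a number. With isopropyl, compound 2 `CC(C)N1C(=O)COc2ccc(-c3cccc(NS(=O)(=O)c4ccc(F)cc4)c3)cc21` gives 22700 nM. With phenyl, compound 3 `O=C1COc2ccc(-c3cccc(NS(=O)(=O)c4ccc(F)cc4)c3)cc2N1c1ccccc1` gives 17700 nM. Compound 3 therefore stands level with compound 2, as the step of a 1.3-fold lower number from compound 2 to compound 3 (0.11 log units; within the scatter) shows.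

Compound 4 `O=C1COc2ccc(-c3cccc(NS(=O)(=O)c4ccc(F)cc4)c3)cc2N1C1CC1` has cyclopropyl in place of phenyl at this nitrogen: cyclopropyl in place of phenyl on an amide-type nitrogen in a ring. Two steps start from the hydrogen: an at least 1.7-fold lower number from compound 1 to compound 2 (0.24 log units; that floor lies within the scatter) and an at least 2.2-fold lower number from compound 1 to compound 3 (0.35 log units; beyond the scatter). Both rest on a limit, so they give only a floor for their size. The closest guide is the exchange of one group for another, a 1.3-fold lower number from compound 2 to compound 3 (0.11 log units; within the scatter), which involves compound 3 and stays within the scatter.

On that basis no step beyond the scatter is expected, and the expected step is a 1.2-fold higher number from compound 3 to compound 4 (0.09 log units; within the scatter). The estimated value for compound 4 is 22000 nM, with an expected range of 11000 nM to 40000 nM.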

Compound 4, half-maximal inhibitory concentration: > 40000 nM
Compound 4 was reported as a limit (the forecaster's own chance of this, stated with the estimate: 20%); middle value at least 1.8-fold (0.25 log units) from the limit.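

Isopropyl and phenyl could not be told apart at this nitrogen, but in this assay the exchange of phenyl for cyclopropyl gives an at least 2.2-fold higher number from compound 3 to compound 4 (0.35 log units; beyond the scatter), so the group here can matter and merely having a ring at this place is not enough to keep the activity of compound 3. The exchange of isopropyl for cyclopropyl gives an at least 1.7-fold higher number from compound 2 to compound 4 (0.24 log units; that floor lies within the scatter), and since that floor lies within the scatter, this step alone does not separate the two groups. The reading for compound 4 is a limit and not a number, and the step from compound 1 to compound 4 cannot be read, because both compounds sit at that limit: the limit of > 40000 nM in this assay, at which 2 of the 4 values shown sit.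

From the compounds shown here alone, whether benzyl, a longer chain such as n-butyl, or a phenyl ring carrying a fluorine or a methoxy group would read lower than compound 3 remains open. Also open, going by these compounds, is whether cyclohexyl, a non-aromatic ring, would read like phenyl or like cyclopropyl.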